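The source may hold more compounds than are shown below. What is called first, only, known or untested is meant among the compounds shown, and "the series" means these compounds.

Measured compounds:
- compound 1, `COc1ccccc1S(=O)(=O)/C=C/c1cccnc1`, 92%
- compound 2, `COc1ccc(S(=O)(=O)/C=C/c2cccnc2)cc1`, 85.8%
- compound 3, `COc1ccccc1S(=O)(=O)/C=C/c1ccncc1`, 78.9%

All three were run in an ADME assay on BV-2 cells (Mus musculus) for cytotoxicity, with a stated time of 24 h, tested at 50 uM; a higher number here means a weaker effect of the compound at the concentration tested, a lower number a stronger effect. Compound 1 gives 92% and compound 2 gives 85.8%; the two differ in more than one place, and the difference between the two cores is not broken down here. Their two values lie within the scatter of each other, so nothing is made of the gap. For the measured compounds named here, compound 3 gives 78.9%, and the step of a number 13.1 percentage points lower from compound 1 to compound 3 (beyond the scatter) is the one counted change in the set, namely (pyridin-4-yl in place of pyridin-3-yl on a double-bonded chain carbon bound to a double-bonded chain carbon).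

Compound 4, `COc1ccc(S(=O)(=O)/C=C/c2ccncc2)cc1`, is not yet measured. It stands to compound 2 as compound 3 stands to compound 1: the change is pyridin-4-yl in place of pyridin-3-yl on a double-bonded chain carbon bound to a double-bonded chain carbon, the same change at the same place. Going by the values given here, on the core of compound 2 this change has not been tested, and only the single step from compound 1 to compound 3 is available as a guide. The expectation is that it repeats. Compound 2 gives 85.8% in this assay. For compound 4 a step of a number 12.8 percentage points lower from compound 2 to compound 4 (beyond the scatter) is estimated from that value, resting on the step of a number 13.1 percentage points lower from compound 1 to compound 3 (beyond the scatter). With one precedent the range is kept wide. Compound 4 is estimated at 73% in this assay, with 60% as the lower end and 86% as the upper end.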

Compound 4, a percentage reported as activity, at one concentration (the size of the read-out at that concentration, not a potency): 69%
Estimate against measurement, compound 4: 4 percentage points above; measured number inside the range.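

In this assay, pyridin-4-yl in place of pyridin-3-yl on a double-bonded chain carbon bound to a double-bonded chain carbon gives a number 16.8 percentage points lower from compound 2 to compound 4 (beyond the scatter), so the change again goes in the same direction as it did on the core of compound 1. Set beside the earlier step, the size of the change also holds from one core to the other: the same change on two cores in this assay, a number 13.1 percentage points lower (beyond the scatter) from compound 1 to compound 3 and a number 16.8 percentage points lower (beyond the scatter) from compound 2 to compound 4, 3.7 percentage points apart, within the scatter of two such steps This supports carrying the change between the cores of compound 1 and compound 2, but it rests on two matched pairs in a single assay at a single concentration, and it neither shows that the step would hold on a further core nor explains why the number falls.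

The compounds shown leave open whether pyridin-2-yl or an unsubstituted phenyl ring on the same chain carbon would fit the same trend. They also leave open whether the step would survive if the methoxy group gave way to a different group, such as a chlorine, an amine or a carboxylic acid.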